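Removal of the dimethylamino group from compound 3

The source may report more compounds than this note shows. Statements on the series, on what has been measured and on what is new or still open speak of the compounds shown alone.

Among the compounds with values here, compound 3 `COc1ccc(S(=O)(=O)N2CCc3cccc(-c4ccc(N(C)C)cc4)c32)cc1` stands highest of the three numbers so far in a functional assay on KB cells (Homo sapiens) for inhibition, with a stated time of 72 h (a lower number here means a stronger inhibitor, a higher number a weaker inhibitor), giving 539 nM. Compound 1 `COc1ccc(S(=O)(=O)N2CCc3cccc(-c4ccc(C#N)cc4)c32)cc1` gives 31.1 nM and compound 2 `COc1ccc(S(=O)(=O)N2CCc3cccc(-c4ccc(F)nc4)c32)cc1` gives 143 nM. The step of a 17-fold higher number from compound 1 to compound 3 (1.24 log units; beyond the scatter) is large and the step of a 3.8-fold higher number from compound 2 to compound 3 (0.58 log units; beyond the scatter) is modest; both lie beyond the scatter, so compound 3 is the weakest inhibitor of the three.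

Compound 4 `COc1ccc(S(=O)(=O)N2CCc3cccc(-c4ccccc4)c32)cc1` differs from compound 3 in one place: hydrogen in place of dimethylamino on an aromatic carbon. Within the data shown here, no measured pair shows hydrogen entering in place of dimethylamino, so the expectation rests on the two steps that end at compound 3. Each of them arrives at the higher number of compound 3 from a different group on the same aromatic carbon, so the group at that position clearly moves the number within this set. Taking the dimethylamino group away altogether is expected to carry compound 4 part of the way back toward the other two, a 2.7-fold lower number from compound 3 to compound 4 (0.43 log units; beyond the scatter), without reaching as far as the step of a 17-fold higher number from compound 1 to compound 3 (1.24 log units; beyond the scatter) spans. For compound 4 the expected value in this assay is 200 nM, with a range from 60 nM to 700 nM.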

Compound 4, half-maximal inhibitory concentration: 120 nM
Estimate against measurement, compound 4: 1.7-fold (0.22 log units) above, within the range that was stated.
By their numbers in this assay, from the lowest: compound 1; then compounds 4 and 2 (each within the scatter of the next); then compound 3.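

With hydrogen on this aromatic carbon, compound 4 gives the position a reference point in this assay: the dimethylamino group and the cyano group lie on opposite sides of it, with a 4.5-fold lower number from compound 3 to compound 4 (0.65 log units; beyond the scatter) when dimethylamino gives way to hydrogen and a 3.9-fold higher number from compound 1 to compound 4 (0.59 log units; beyond the scatter) when hydrogen replaces cyano. The phenyl and 6-fluoropyridin-3-yl groups cannot be told apart at this position, with a 1.2-fold lower number from compound 2 to compound 4 (0.08 log units; within the scatter), so the change from carbon-only phenyl to the fluorinated pyridine ring leaves no readable mark on the number in this pair. No measurement at hand accounts for any of these steps.

As far as these compounds go, whether a primary amine, a carboxylic acid or a simple methyl group on the same aromatic carbon would fall with dimethylamino, with hydrogen or with cyano remains open, so the four compounds give no general ordering of groups at this position. All four compounds also share the same methoxy-bearing sulfonyl part, which leaves open whether these steps would keep their size if that methoxy group were replaced by, for example, a chlorine atom or a longer alkoxy chain.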